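Taking the methyl off compound 1: an expected step

The compounds below may be only part of what the source reports. "The series", "measured", "known", "first", "only" and "open" are said of these compounds alone.

Measured in a functional assay on M14 cells (Homo sapiens) for cytotoxicity, read by resazurin assay, with a stated time of 72 h; on this read-out higher numbers stand for weaker inhibition and lower numbers for stronger inhibition:
Compound 1 `COc1cc(/C=C/C(=O)OCCCO[N+](=O)[O-])ccc1OCCCO[N+](=O)[O-]`: > 50000 nM (a limit)
Compound 2 `COc1cc(/C=C/C(=O)OC(C)CCOc2no[n+]([O-])c2S(=O)(=O)c2ccccc2)ccc1O`: 410 nM
Compound 3 `COc1cc(/C=C/C(=O)OCCCO[N+](=O)[O-])ccc1O`: 42600 nM

Compound 1 has no number of its own, only a limit: it stands at the limit of > 50000 nM in this assay, at which 1 of the 3 values shown sits. Compound 4 `O=C(/C=C/c1ccc(OCCCO[N+](=O)[O-])c(O)c1)OCCCO[N+](=O)[O-]` has not yet been measured. It differs from compound 1 by hydrogen in place of methyl on an oxygen on an aromatic ring, that is, methoxy to hydroxy, and it keeps the ester chain of compound 1.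

Going by the values given here, one measured step bears on this change, though only loosely. It also leaves a hydrogen on an oxygen on an aromatic ring, but the group that goes is 3-(nitrooxy)propyl rather than methyl. That step is an at least 1.1-fold lower number from compound 1 to compound 3 (0.06 log units; that floor lies within the scatter), with compound 3 at 42600 nM. Compound 2 gives 410 nM, but it differs from compound 1 in more than one place and offers no guide here.

Resting on an at least 1.1-fold lower number from compound 1 to compound 3 (0.06 log units; that floor lies within the scatter), only a small step is expected in this assay, towards a lower number if there is one, and it may not exceed the scatter. The expected step is an at least 1.4-fold lower number from compound 1 to compound 4 (0.15 log units; that floor lies within the scatter). For compound 4 the estimated value is 35000 nM, with an expected range from 10000 nM to 70000 nM.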

Compound 4, half-maximal inhibitory concentration: 8960 nM
The estimate for compound 4 lay 3.9-fold (0.59 log units) above the measured number; measured number below the stated range.
By their numbers in this assay, from the lowest: compound 2; then compound 4; then compound 3. At a limit, above all of these: compound 1.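

In this assay, the change from methoxy to hydroxy, with the ester chain left as it was, comes with an at least 5.5-fold lower number from compound 1 to compound 4 (0.74 log units; beyond the scatter). This is the first step on an oxygen on an aromatic ring that clearly exceeds the scatter, whereas the earlier one, an at least 1.1-fold lower number from compound 1 to compound 3 (0.06 log units; that floor lies within the scatter), had a floor that could not be told apart from it, so the methoxy position is now shown to respond to the loss of a single methyl. The true size of the step remains unknown, as compound 1 carries only a limit and not a number: the limit of > 50000 nM in this assay, at which 1 of the 4 values shown sits.

The compounds shown leave open whether the step depends on the hydrogen itself, or whether an ethyl group, an acetyl group or a longer chain on that oxygen would also bring the number down from the limit of compound 1. They also leave open whether methoxy to hydroxy gives a step of similar size on a compound with a different ester chain, or with an amine in place of the 3-(nitrooxy)propyl group.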